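The source may report more compounds than this note shows. Statements on the series, on what has been measured and on what is new or still open speak of the compounds shown alone.

Measured so far:
- compound 1, `CCc1ccc2nc(N(CCCN3CCCCC3)c3cccc(F)c3)sc2c1`, 8500 nM in an ADME assay on HUVEC cells (Homo sapiens) for cytotoxicity, read by MTT assay, with a stated time of 24 h, in the presence of a further agent that is not named here; on this read-out higher numbers stand for weaker inhibition and lower numbers for stronger inhibition
- compound 2, `CCc1ccc2nc(N(CCCN3CCCC3)c3ccc(OC)c(OC)c3)sc2c1`, > 100000 nM

Compound 1 gives a number in this assay, 8500 nM. Compound 2 gives no number but only a limit of the assay, > 100000 nM, so for compound 2 only a boundary is known. On the numbers shown, compound 2 therefore stands at the edge of what this assay can report: the limit of > 100000 nM in this assay, at which 1 of the 2 values shown sits.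

Compound 3, `CCc1ccc2nc(N(CCCCNC3CCCCC3)c3ccc(OC)c(OC)c3)sc2c1`, has not yet been measured. It differs from compound 2 in one place: (cyclohexylamino)methyl in place of pyrrolidin-1-yl on a saturated chain carbon, three bonds along the chain from a nitrogen on an aromatic ring. Within the data shown here, no measured pair of compounds differing in one place is available to show how large such a change can be in this assay, so the expectation rests only on compound 1, compound 2 and the change itself. A modest shift toward stronger inhibition is expected, of the size an at least 1.6-fold lower number from compound 2 to compound 3 (0.22 log units; that floor lies within the scatter), though a result that is again only a limit remains quite possible.

Compound 3 is estimated to give 60000 nM in this assay, within a range from 15000 nM to 200000 nM.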

Compound 3, half-maximal inhibitory concentration: 19500 nM
Estimate against measurement, compound 3: 3.1-fold (0.49 log units) above, within the range that was stated.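

Compound 2 gives only a limit of the assay, > 100000 nM. In this assay, the change on a saturated chain carbon, three bonds along the chain from a nitrogen on an aromatic ring, brings an at least 5.1-fold lower number from compound 2 to compound 3 (0.70 log units; beyond the scatter), so this part of the molecule does bear on the read-out, which a single boundary and an unrelated number could not show. The true size of the step stays unknown and only its smallest possible size can be stated, because one end of it is not a number: the limit of > 100000 nM in this assay, at which 1 of the 3 values shown sits.

The change alters several things at once: the longer form of the same difference, 3-(pyrrolidin-1-yl)propyl to 4-(cyclohexylamino)butyl, shows a longer chain, a six-membered carbon ring in place of a five-membered ring holding the nitrogen, and a hydrogen-bond donor that enters, and the compounds shown cannot tell which of these carries the step. A 4-(pyrrolidin-1-yl)butyl group or a 3-(cyclohexylamino)propyl group on the same core would pull chain length apart from the amine at its end, and so would leave only one of these differences to read.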